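The compounds below may be only part of what the source reports. "The series", "measured", "known", "first", "only" and "open" are said of these compounds alone.

In a functional assay on HepG2 cells (Homo sapiens) for cytotoxicity, read by MTT assay, with a stated time of 72 h (a higher number here means a weaker inhibitor, a lower number a stronger inhibitor), the measured compounds read:
- compound 1 `C=C(C)[C@@H]1CC[C@](C)(O)[C@H]1/C=C/C(C)=C/[C@@H]1C[C@@]23[C@H](OCCC[C@@H]2/C(=C(/C)C=O)CC[C@]3(C)O)O1` gives > 10000 nM
- compound 2 `C=C(C)[C@@H]1CC[C@](C)(O)[C@H]1/C=C/C(C)=C/[C@@H]1C[C@@]23[C@H](OCCC[C@@H]2/C(=C(\C)C=O)CC[C@]3(C)O)O1` gives > 10000 nM
- compound 3 `C=C(C)[C@@H]1CC[C@](C)(O)[C@H]1/C=C/C(C)=C/[C@@H]1C[C@@]2([C@H](OC)O1)[C@H](CCCO)/C(=C(/C)C=O)CC[C@]2(C)O` gives > 10000 nM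

Each entry is a limit and not a number.

Compound 3 reads > 10000 nM as a limit of the assay. Among the measured compounds shown here, the series so far offers only the limit of > 10000 nM in this assay, at which 3 of the 3 values shown sit, and no number. Compound 4 `C=C(C)[C@H]1CC[C@@](C)(O)[C@@H]1/C=C/C(C)=C/[C@@H]1C[C@@]2([C@H](OC)O1)[C@H](CCCO)/C(=C(/C)C=O)CC[C@]2(C)O` shows the two compounds have the same atoms and bonds and differ only in configuration as drawn: 3 of 11 stereo elements differ; a stereocentre at a saturated ring carbon is drawn R in compound 3 and S in compound 4; a stereocentre at a saturated ring carbon is drawn S in compound 3 and R in compound 4; a stereocentre at a saturated ring carbon is drawn S in compound 3 and R in compound 4 and no other change. For the measured compounds named here, the one measured step of this kind is a step that the two limits leave unreadable from compound 1 to compound 2 and it rests on the fact that compounds 1 and 2 differ only in the configuration as drawn so it gives no size to carry over. No direction can be read from it either. The expected change is a step that the limit leaves unreadable from compound 3 to compound 4 with no step beyond the scatter foreseen. For compound 4 the estimate is 15000 nM with 6000 nM to 40000 nM as the expected span.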

Compound 4, half-maximal inhibitory concentration: > 10000 nM
Compound 4 ended at the assay's limit; the forecaster's own chance of this, stated with the estimate: 85%; the middle value does not contradict the limit.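

In this assay compound 4 gives > 10000 nM, a limit of the assay, as compound 3 also does, so no step can be read between them. The compounds shown leave open whether any change in drawn configuration alters the read-out in this assay.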